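Methoxy removal on the aryl ketone side: notes before measurement

The compounds below may be only part of what the source reports. "The series", "measured", "known", "first", "only" and "open" are said of these compounds alone.

Measured so far in a functional assay on RXF 393 cells (Homo sapiens) for cytotoxicity, read by sulforhodamine B assay, with a stated time of 48 h, tested at 0.01 uM; a higher number here means a weaker effect of the compound at the concentration tested, a lower number a stronger effect:
compound 1, `COc1ccc(-c2cc(/C=C/C(=O)c3ccc(N)cc3)[nH]n2)cc1`, gives 95%
compound 2, `COc1ccc(-c2cc(/C=C/C(=O)c3ccc(N)cc3)[nH]n2)cc1OC`, gives 99%
compound 3, `COc1cc(C(=O)/C=C/c2cc(-c3cc(OC)c(OC)c(OC)c3)n[nH]2)cc(OC)c1OC`, gives 93%

The three numbers lie close together. Compound 3 has the lowest of the three, but its gaps to compound 1 and to compound 2 are within the scatter, so no order is read from them. One structural change is made twice in the set. From compound 2 to compound 1 it is hydrogen in place of methoxy on an aromatic carbon and it moved this assay by a number 4 percentage points lower from compound 2 to compound 1 (within the scatter). The difference between the core of compound 2 and the core of compound 3 is not broken down here. Compound 4, `COc1ccc(-c2cc(/C=C/C(=O)c3cc(OC)c(OC)c(OC)c3)[nH]n2)cc1OC`, follows from compound 3 by the same kind of change, (hydrogen in place of methoxy on an aromatic carbon); the surroundings are not identical, since in compound 3 the place is also meta to a methoxy group. Much the same is expected here, no change at the digits printed from compound 3 to compound 4 (within the scatter), because the earlier step of a number 4 percentage points lower from compound 2 to compound 1 (within the scatter) stayed within the scatter. Compound 4 is accordingly estimated at 93%, with a likely range from 83% to 103%.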

Compound 4, a percentage reported as activity, at one concentration (the size of the read-out at that concentration, not a potency): 103%
The estimate for compound 4 lay 10 percentage points below the measured number; low and high end bracket the measured number.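

In this assay, hydrogen in place of methoxy on an aromatic carbon gives a number 10 percentage points higher from compound 3 to compound 4 (within the scatter). Set beside the earlier step on the other core, the result gives no sign that the change behaves differently on the two cores: the same change on two cores in this assay, a number 4 percentage points lower (within the scatter) from compound 2 to compound 1 and a number 10 percentage points higher (within the scatter) from compound 3 to compound 4, 14 percentage points apart, within the scatter of two such steps This supports carrying the change between these two cores only in a limited sense, as neither step can be told from the scatter; it does not show that the two steps are equal, that the methoxy group is without effect, or that the result would hold on a core with a clearly lower number.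

From the compounds shown here alone, what a chlorine atom, a carboxylic acid or a longer chain such as ethoxy would do on that aromatic carbon in this assay stays open. The read-out at one concentration also leaves open how these compounds compare at other concentrations.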